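Alpha-Methylation of the Anilide Chain in Sulfonate Esters

The compounds below may be only part of what the source reports. "The series", "measured", "known", "first", "only" and "open" are said of these compounds alone.

Compound 1, `CCC(=O)Nc1cccc(S(=O)(=O)Oc2ccccc2C(C)C)c1`, gives 25000 nM in a functional assay on M21 cells (Homo sapiens) for antiproliferative activity, read by sulforhodamine B assay, with a stated time of 48 h; on this read-out lower numbers stand for stronger inhibition and higher numbers for weaker inhibition. Compound 2, `CC(C)C(=O)Nc1cccc(S(=O)(=O)Oc2ccccc2C(C)C)c1`, gives 17000 nM in this assay. Compound 3, `CC(C)C(=O)Nc1ccc(S(=O)(=O)Oc2ccccc2C(C)C)cc1`, gives 11000 nM in this assay.

Compound 2 differs from compound 1 by methyl in place of hydrogen on a saturated chain carbon bound to a carbonyl carbon and a saturated chain carbon, and this gave a 1.5-fold lower number from compound 1 to compound 2 (0.17 log units; within the scatter). Compound 3 shares the isopropylcarbonylamino group with compound 2 but carries it on a different core; the difference between the two cores is not broken down here. Compound 3 shows the lowest number of the three, while the two values of compound 3 and compound 2 lie within the scatter of each other.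

Compound 4, `CC(C)c1ccccc1OS(=O)(=O)c1ccc(NC(=O)C(C)(C)C)cc1`, differs from compound 3 by methyl in place of hydrogen on a saturated chain carbon bound to a carbonyl carbon and two saturated chain carbons. This is the same kind of change as that from compound 1 to compound 2, though the place is not the same: there the saturated chain carbon is bound to a carbonyl carbon and a saturated chain carbon, here to a carbonyl carbon and two saturated chain carbons. Because the earlier step gave a 1.5-fold lower number from compound 1 to compound 2 (0.17 log units; within the scatter), compound 4 is expected to give a step of a 1.4-fold lower number from compound 3 to compound 4 (0.14 log units; within the scatter), in this assay, staying within the scatter. Compound 4 is thus estimated at 8000 nM, within 4000 nM to 16000 nM.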

Compound 4, half-maximal inhibitory concentration: 6200 nM
Beside the measured number, compound 4's estimate is 1.3-fold (0.11 log units) above it; the range from low to high includes it.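

Replacing hydrogen with methyl on the saturated chain carbon bound to a carbonyl carbon and two saturated chain carbons, which turns isopropyl into tert-butyl, gave a 1.8-fold lower number from compound 3 to compound 4 (0.25 log units; within the scatter) in this assay. Set beside the earlier step, the change carries from one core to the other with no difference that can be told apart: the same change on two cores in this assay, a 1.5-fold lower number (0.17 log units; within the scatter) from compound 1 to compound 2 and a 1.8-fold lower number (0.25 log units; within the scatter) from compound 3 to compound 4, 1.2-fold (0.08 log units) apart, within the scatter of two such steps. Each step on its own lies within the scatter, however, so neither pair establishes a real effect of the methyl, and two pairs at differently bound carbons give no rule for further cores.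

The compounds shown leave open whether a longer chain, a cyclopropyl group or an amine in place of the tert-butyl would move the number beyond the scatter. They also leave open how the step would behave if the isopropyl group of the ester part gave way to a methoxy group or a chlorine atom.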